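Cyclopropylmethyl in place of propyl on the lactam nitrogen

The source may report more compounds than this note shows. Statements on the series, on what has been measured and on what is new or still open speak of the compounds shown alone.

Compound 1 `O=C(O)c1cc(-c2cccc(COc3ccc4c(c3)CN(c3ccccc3)C4=O)c2)ccc1Cl`: in an assay on HEK293 cells for positive allosteric modulation of metabotropic glutamate receptor 2 (Rattus norvegicus), read by thallium flux (a lower number here means a smaller maximal response, a higher number a larger maximal response), compound 1 gives 86.2%.
Compound 2 `CC(C)N1Cc2cc(OCc3cccc(-c4ccc(Cl)c(C(=O)O)c4)c3)ccc2C1=O`: in this assay compound 2 gives 88.1%.
Compound 3 `CCCN1Cc2cc(OCc3cccc(-c4ccc(Cl)c(C(=O)O)c4)c3)ccc2C1=O`: in this assay compound 3 gives "not determined" (no result reported), that is, no result for compound 3 was reported.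

Compound 3 therefore stands on no number of its own in this assay; what is known comes from compound 1 and compound 2, whose values lie close together. Among the measured compounds shown here, the one measured step changes the group on the amide-type nitrogen in the ring: a number 1.9 percentage points higher from compound 1 to compound 2 (within the scatter), a change that left the maximal response essentially where it was.

Compound 4 `O=C(O)c1cc(-c2cccc(COc3ccc4c(c3)CN(CC3CC3)C4=O)c2)ccc1Cl` differs from compound 3 by cyclopropyl in place of ethyl on a saturated chain carbon bound to an amide-type nitrogen in a ring. This change sits in the same region of the shared core as the measured step, one bond further out from the nitrogen. Since that neighbouring step moved the read-out only within the scatter, no step beyond the scatter is expected here either, in either direction. Compound 4 is therefore estimated to give 87% in this assay, with a range of 74% to 100%.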

Compound 4, largest response reached (Emax), in percent of the reference or control that the assay uses: 85.7%
For compound 4 the middle estimate is 1.3 percentage points above the measured one; the range from low to high includes it.
By their numbers in this assay, from the lowest: compounds 4, 1 and 2 (each within the scatter of the next).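

In this assay the cyclopropylmethyl group keeps the maximal response level with both earlier groups on the amide-type nitrogen in a ring: the change from isopropyl gives a number 2.4 percentage points lower from compound 2 to compound 4 (within the scatter), and the change from phenyl gives a number 0.5 percentage points lower from compound 1 to compound 4 (within the scatter). Across compound 1, compound 2 and compound 4, then, this nitrogen carries phenyl, isopropyl or cyclopropylmethyl with no step beyond the scatter, so a three-membered ring set one carbon out from the nitrogen does as well here as a phenyl ring bound directly to it. The information at hand offers no explanation for why the read-out stays this flat.

From the compounds shown here alone, the steps from compound 3 to the other compounds cannot be read, so the effect of propyl to cyclopropylmethyl remains unknown. Going by these compounds, it also remains open whether a longer chain such as butyl, or a chain ending in an amine, would leave the maximal response at this level.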